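A catechol ester joins a series reported only as limits

This account rests on a few compounds, and the source may have more. Where it says the series, first, only, none or still open, it means among the compounds named here.

Compound 1 (`C/C=C1/[C@H](O[C@@H]2O[C@H](CO)[C@@H](O)[C@H](O)[C@H]2O)OC=C(C(=O)OC)[C@H]1CC(=O)OCCCc1ccc(OC)c(OC)c1`): > 20000 nM (a limit)
Compound 2 (`C/C=C1/[C@H](O[C@@H]2O[C@H](CO)[C@@H](O)[C@H](O)[C@H]2O)OC=C(C(=O)OC)[C@H]1CC(=O)OCCC`): > 15000 nM (a limit)
Compound 3 (`C=C(C)CCOC(=O)C[C@@H]1C(C(=O)OC)=CO[C@@H](O[C@@H]2O[C@H](CO)[C@@H](O)[C@H](O)[C@H]2O)/C1=C/C`): > 15000 nM (a limit)

In a functional assay on SK-BR-3 cells (Homo sapiens) for antiproliferative activity, read by MTT assay, with a stated time of 72 h (on this read-out lower numbers stand for stronger inhibition and higher numbers for weaker inhibition), compound 3 gives (> 15000 nM), which is a limit. Neither of the other two compounds has a number either, so compound 3 cannot be ranked against them.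

Compound 4 (`C/C=C1/[C@H](O[C@@H]2O[C@H](CO)[C@@H](O)[C@H](O)[C@H]2O)OC=C(C(=O)OC)[C@H]1CC(=O)OCCc1ccc(O)c(O)c1`) carries 3,4-dihydroxyphenyl in place of 1-methylethenyl on a saturated chain carbon, two bonds along the chain from an oxygen next to a carbonyl group.

Among the compounds with values here, the closest measured change is the one that also exchanges an aromatic group for 1-methylethenyl (a step that the two limits leave unreadable from compound 1 to compound 3). The other two steps (a step that the two limits leave unreadable from compound 1 to compound 2) and (a step that the two limits leave unreadable from compound 2 to compound 3) are no more informative. None of the three has a readable size, so they offer no direction for this change, and no step beyond the scatter can be predicted.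

The expected outcome is a step with no clear gain (a step that the limit leaves unreadable from compound 3 to compound 4). Compound 4 is expected to stay weak in this assay and may well return only a limit. For compound 4 the estimated value is (30000 nM), with an expected range from (12000 nM) to (100000 nM).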

Compound 4, half-maximal inhibitory concentration: 160000 nM
Estimate against measurement, compound 4: 5.3-fold (0.73 log units) below, outside the stated range (above it).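

Within the data shown here, compound 4 has a number, but no step to it from compound 1, compound 2 or compound 3 can be read, because those three stand only at limits: the limit of > 15000 nM in this assay, at which 2 of the 4 values shown sit. Compound 1 holds the other limit: the limit of > 20000 nM in this assay, at which 1 of the 4 values shown sits. On these data alone, whether 3,4-dihydroxyphenyl in place of 1-methylethenyl brings any real change in this assay stays open.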